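Cyclopropyl for 4-methylphenyl in a weakly active series

The compounds below may be only part of what the source reports. "The series", "measured", "known", "first", "only" and "open" are said of these compounds alone.

Going by the values given here, in a functional assay on HCT-116 cells (Homo sapiens) for antiproliferative activity, read by MTT assay, with a stated time of 72 h (on this read-out higher numbers stand for weaker inhibition and lower numbers for stronger inhibition), compound 1 `COc1ncc(-c2ccc3c(c2)N(c2ccc(C)cc2)C(=O)CO3)cc1NS(=O)(=O)c1ccc(F)cc1` gives 22700 nM and is the only compound so far with a measured number. Compound 2 `COc1cccc(N2C(=O)COc3ccc(-c4cccc(NS(=O)(=O)c5ccc(F)cc5)c4)cc32)c1` reads > 40000 nM in this assay and this is a limit of the assay, not a number.

The next compound to be read is compound 3 `COc1ncc(-c2ccc3c(c2)N(C2CC2)C(=O)CO3)cc1NS(=O)(=O)c1ccc(F)cc1`. Its difference from compound 1 (cyclopropyl in place of 4-methylphenyl on an amide-type nitrogen in a ring) is cyclopropyl in place of 4-methylphenyl on an amide-type nitrogen in a ring, three ring bonds from the ring oxygen. Among the compounds with values here, no measured pair shows a change at this place, so the expectation rests on compound 1 at 22700 nM as the starting point. The estimated step of a 1.1-fold higher number from compound 1 to compound 3 (0.04 log units; within the scatter) is expected to stay within the usual scatter, with no clear direction. For compound 3 the estimate is 25000 nM (expected range 9000 nM to 40000 nM).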

Compound 3, half-maximal inhibitory concentration: 24300 nM
For compound 3 the middle estimate is 1.0-fold (0.01 log units) above the measured one, within the range that was stated.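

In this assay, the change at this position gives a 1.1-fold higher number from compound 1 to compound 3 (0.03 log units; within the scatter), so the first step read here does not separate cyclopropyl from 4-methylphenyl on the amide-type nitrogen in a ring. For this pair, a group of 3 heavy atoms and a group of 7 heavy atoms give values within the scatter, and the six-membered aromatic ring of carbon is not required to keep the activity of compound 1. Compound 2 differs from compound 1 in more than one place and reads at a limit of the assay, which is not a number: the limit of > 40000 nM in this assay, at which 1 of the 3 values shown sits.

From the compounds shown here alone, whether a longer chain or a group carrying an amine or a carboxylic acid on this nitrogen would move the number beyond the scatter stays open. The compounds shown also leave open whether any group at this position gives a clearly lower number.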